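Same Substituent Swap, Read Across a Stereocentre

A few compounds are considered here, and "the series" means these few. Any claim that something is new, unique, unknown or untested is made for them only; others in the source may bear on it.

Compound 2 `CN1CCN(c2ccc(Nc3ncc4nc(Nc5ccc(F)cc5)n([C@@H]5CCN(S(=O)(=O)C6CC6)C5)c4n3)cc2)CC1` and compound 3 `CN1CCN(c2ccc(Nc3ncc4nc(Nc5ccc(F)cc5)n([C@H]5CCN(S(=O)(=O)C6CC6)C5)c4n3)cc2)CC1` are built from the same atoms and bonds; (the two compounds have the same atoms and bonds and differ only in configuration as drawn: 1 of 1 stereo elements differ; a stereocentre at a saturated ring carbon is drawn R in compound 2 and S in compound 3). In a functional assay on HCC827 cells (Homo sapiens) for antiproliferative activity, read by MTT assay, with a stated time of 72 h (on this read-out higher numbers stand for weaker inhibition and lower numbers for stronger inhibition), compound 2 gives 2.5 nM and compound 3 gives 7.5 nM, so a 3.0-fold higher number from compound 2 to compound 3 (0.48 log units; beyond the scatter), a gap that goes with the fact that compounds 2 and 3 differ only in the configuration as drawn. Compound 1 `CN1CCN(c2ccc(Nc3ncc4nc(Nc5ccc(F)cc5)n([C@@H]5CCN(C(=O)CO)C5)c4n3)cc2)CC1` differs from compound 2 in one place: (hydroxymethyl)carbonyl in place of cyclopropylsulfonyl on an amine nitrogen in a ring. In this assay compound 1 gives 350 nM, and a 140-fold higher number from compound 2 to compound 1 (2.15 log units; beyond the scatter). Compound 4 `CN1CCN(c2ccc(Nc3ncc4nc(Nc5ccc(F)cc5)n([C@H]5CCN(C(=O)CO)C5)c4n3)cc2)CC1` has not yet been measured; it differs from compound 3 by the same change, ((hydroxymethyl)carbonyl in place of cyclopropylsulfonyl on an amine nitrogen in a ring), at a place described in exactly the same words. Compound 4 is therefore expected to show a 120-fold higher number from compound 3 to compound 4 (2.08 log units; beyond the scatter), an estimated value of about 900 nM, likely between 300 nM and 3000 nM. That expectation rests on compound 1 and the step of a 140-fold higher number from compound 2 to compound 1 (2.15 log units; beyond the scatter), where the same group was swapped at the same place.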

Compound 4, half-maximal inhibitory concentration: 380 nM
Compound 4: middle estimate off by 2.4-fold (0.37 log units), on the high side; measured number inside the range.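

In this assay, putting (hydroxymethyl)carbonyl in place of cyclopropylsulfonyl again gives a large loss on the second core, with a 51-fold higher number from compound 3 to compound 4 (1.70 log units; beyond the scatter), but the size of the step does not carry over exactly: the same change on two cores in this assay, a 140-fold higher number (2.15 log units; beyond the scatter) from compound 2 to compound 1 and a 51-fold higher number (1.70 log units; beyond the scatter) from compound 3 to compound 4, 2.8-fold (0.44 log units) apart, beyond the scatter of two such steps

Changing the group and the configuration together gives a 150-fold higher number from compound 2 to compound 4 (2.18 log units; beyond the scatter), while changing the configuration alone, with (hydroxymethyl)carbonyl in place, gives a 1.1-fold higher number from compound 1 to compound 4 (0.04 log units; within the scatter): the fact that compounds 1 and 4 differ only in the configuration as drawn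

These compounds do not show why the swap costs so much, nor whether it would cost as much on any other core.

Left open is whether methylsulfonyl or acetyl on that ring nitrogen would behave like cyclopropylsulfonyl or like (hydroxymethyl)carbonyl. As far as these compounds go, it is also open whether either group would show a gap between the two configurations.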